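The source may report more compounds than this note shows. Statements on the series, on what has been measured and on what is new or still open speak of the compounds shown alone.

Compound 1 `CCCCC#Cc1cc(C(=O)OCC)nc2ccc(OC)cc12` gives 15900 nM
Compound 2 `COc1ccc([Se]c2cc(-c3ccc(O)cc3)nc3ccc(OC)cc23)cc1` gives 41500 nM

Both numbers come from a functional assay on Jurkat cells (Homo sapiens) for cytotoxicity, read by MTT assay, with a stated time of 24 h; a lower number here means that less compound is needed, a higher number that more compound is needed for the effect. Compound 1 holds the lower of the two numbers, and its gap to compound 2 lies beyond the usual scatter, so less of compound 1 is needed for the effect.

Compound 3 `CCOC(=O)c1cc([Se]c2ccccc2)c2cc(OC)ccc2n1` has not yet been measured. It keeps the core of compound 1 and its ethoxycarbonyl group, but the hex-1-yn-1-yl group is exchanged: a group of 7 heavy atoms (6 carbon, 1 selenium; one six-membered aromatic ring of carbon only) in place of a group of 6 heavy atoms (6 carbon; no ring), on an aromatic carbon. The exchange sits on an aromatic carbon opposite the ring nitrogen, and the entering group holds a selenium atom and a six-membered aromatic ring of carbon only.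

Among the compounds with values here, no measured pair shows this exchange alone, so any forecast is rough. Within the data shown here, compound 2, the only measured compound with selenium, gives 41500 nM as its number, and that pulls the expectation upward. The expected step of a 1.6-fold higher number from compound 1 to compound 3 (0.20 log units; within the scatter) is therefore small and towards a higher number. For compound 3 the estimated value is 25000 nM with an expected range from 10000 nM to 65000 nM.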

Compound 3, half-maximal effective concentration: 102000 nM
Compound 3: the middle estimate sits 4.1-fold (0.61 log units) below what was measured; the measured number lies above the stated range.
By their numbers in this assay, from the lowest: compound 1; then compound 2; then compound 3.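

In this assay, replacing hex-1-yn-1-yl with a group holding selenium and a six-membered aromatic ring of carbon only, on the aromatic carbon opposite the ring nitrogen, brings a 6.4-fold higher number from compound 1 to compound 3 (0.81 log units; beyond the scatter). The core and the ethoxycarbonyl group stay the same, so this single pair shows that the group at this position can change how much compound is needed for the cytotoxic effect, and that this exchange raises the amount needed. No measurement shown here explains this step.

From the compounds shown here alone, the exchange alters several things at once, removing a triple bond and bringing in both selenium and an aromatic ring, and which of these changes carries the step remains open. Also open, going by these compounds, is how this position would respond to a phenyl group joined directly to the aromatic carbon, to a sulfur atom in place of the selenium, or to a saturated hexyl chain in place of hex-1-yn-1-yl.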